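The compounds below may be only part of what the source reports. "The series", "measured", "known", "first", "only" and "open" are said of these compounds alone.

Of the compounds shown here, three sharing one core have been measured in a functional assay on A549 cells (Homo sapiens) for inhibition, read by MTT assay, with a stated time of 72 h, tested at 20 uM; a higher number here means more inhibition at the concentration tested (going by the name of the read-out), a lower number less inhibition. Compound 2 `c1cc(N2CCCC2)nc(Nc2ccc(Oc3ncnc4sccc34)cc2)n1` gives 61%. Compound 1 `CN(c1ccc(Oc2ncnc3sccc23)cc1)c1nccc(N2CCCC2)n1` differs from it by methyl in place of hydrogen on a nitrogen on an aromatic ring, and in this assay compound 1 gives 55.5%, a step of a number 5.5 percentage points lower from compound 2 to compound 1 (within the scatter). Compound 3 `c1ccc2c(c1)CCN(c1ccnc(Nc3ccc(Oc4ncnc5sccc45)cc3)n1)C2` differs from compound 2 in its core by 1,2,3,4-tetrahydroisoquinolin-2-yl in place of pyrrolidin-1-yl on an aromatic carbon; in this assay compound 3 gives 34%, and the step of a number 27 percentage points lower from compound 2 to compound 3 (beyond the scatter) leaves compound 3 with the lowest number of the three.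

Compound 4 `CN(c1ccc(Oc2ncnc3sccc23)cc1)c1nccc(N2CCc3ccccc3C2)n1` has not been measured. It differs from compound 3 by methyl in place of hydrogen on a nitrogen on an aromatic ring, the same change that turned compound 2 into compound 1 and there made the step of a number 5.5 percentage points lower from compound 2 to compound 1 (within the scatter). On the core of compound 3 this change is expected to make a step of about a number 4 percentage points lower from compound 3 to compound 4 (within the scatter), because the earlier step of a number 5.5 percentage points lower from compound 2 to compound 1 (within the scatter) stayed within the scatter, and this single precedent gives no reason to expect more on a different core. Compound 4 is therefore estimated at 30%, most likely between 15% and 45%.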

Compound 4, a percentage reported as inhibition, at one concentration (the size of the read-out at that concentration, not a potency): 68.4%
Compound 4: middle estimate off by 38.4 percentage points, on the low side; the whole stated range lies below it.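

In this assay, methyl in place of hydrogen on a nitrogen on an aromatic ring makes a step of a number 34.4 percentage points higher from compound 3 to compound 4 (beyond the scatter), so this change did not carry over from one core to the other with the same size: the same change on two cores in this assay, a number 5.5 percentage points lower (within the scatter) from compound 2 to compound 1 and a number 34.4 percentage points higher (beyond the scatter) from compound 3 to compound 4, 39.9 percentage points apart, beyond the scatter of two such steps. The exchange of the other group reads the same way, with 1,2,3,4-tetrahydroisoquinolin-2-yl in place of pyrrolidin-1-yl on an aromatic carbon making a step of a number 12.9 percentage points higher from compound 1 to compound 4 (beyond the scatter), which does not match the earlier step for that exchange: the same change on two cores in this assay, a number 27 percentage points lower (beyond the scatter) from compound 2 to compound 3 and a number 12.9 percentage points higher (beyond the scatter) from compound 1 to compound 4, 39.9 percentage points apart, beyond the scatter of two such steps. These four compounds show that the two changes do not add up independently here, but they do not show why, and a read-out at one concentration says nothing about potency.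

On these data alone, whether the methyl step depends in the same way on other groups in that place, such as piperidin-1-yl or morpholin-4-yl, remains open. As far as these compounds go, it is also open whether a longer chain on that nitrogen, such as ethyl, would behave like methyl.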